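A few compounds are considered here, and "the series" means these few. Any claim that something is new, unique, unknown or untested is made for them only; others in the source may bear on it.

Measured so far in a functional assay on NCI-H460 cells (Homo sapiens) for cytotoxicity, read by MTT assay, with a stated time of 72 h; a lower number here means a stronger inhibitor, a higher number a weaker inhibitor:

compound 1 `CC1CCN(Cc2ccc3nc(NC(=O)N/N=C/c4cn(Cc5ccc(Cl)cc5Cl)c5ccccc45)sc3c2)CC1`: 1660 nM
compound 2 `CC1CCN(Cc2ccc3nc(NC(=O)N/N=C/c4cn(Cc5cccc(Cl)c5)c5ccccc45)sc3c2)CC1`: 280 nM
compound 3 `CCN(CC)Cc1ccc2nc(NC(=O)N/N=C/c3cn(Cc4ccc(C)cc4)c4ccccc34)sc2c1`: 320 nM

Compound 3 stands second highest of the three numbers. Its nearest neighbour is compound 2, whose number lies within the scatter of that of compound 3; compound 1 lies beyond the scatter, with the higher number. Going by the values given here, the only step measured between single-point neighbours is a 5.9-fold lower number from compound 1 to compound 2 (0.77 log units; beyond the scatter); it concerns the group on the saturated chain carbon bound to the aromatic nitrogen, not the part changed here, and so gives no direct guide.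

Compound 4 `Cc1ccc(Cn2cc(/C=N/NC(=O)Nc3nc4ccc(CN5CCC(C)CC5)cc4s3)c3ccccc32)cc1` differs from compound 3 in one place: 4-methylpiperidin-1-yl in place of diethylamino on a saturated chain carbon bound to an aromatic carbon. Compound 2 already carries 4-methylpiperidin-1-yl at this position, but it also differs from compound 3 elsewhere, so its closeness to compound 3 in this assay cannot be attributed to either change alone. Among the compounds with values here, with no measured step bearing on this exchange, the expectation for compound 4 is a step not beyond the scatter, a 1.1-fold lower number from compound 3 to compound 4 (0.03 log units; within the scatter). Compound 4 is therefore estimated at 300 nM, with a range from 110 nM to 800 nM.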

Compound 4, half-maximal inhibitory concentration: 410 nM
For compound 4 the middle estimate is 1.4-fold (0.14 log units) below the measured one; measured number inside the range.
By their numbers in this assay, from the lowest: compounds 2, 3 and 4 (each within the scatter of the next); then compound 1.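

In this assay, 4-methylpiperidin-1-yl in place of diethylamino on the saturated chain carbon bound to an aromatic carbon gives a 1.3-fold higher number from compound 3 to compound 4 (0.11 log units; within the scatter) so this exchange to a six-membered ring, read with 4-methylphenyl held fixed, makes no difference beyond the scatter. Going by these compounds alone, with 4-methylpiperidin-1-yl held fixed, the group on the saturated chain carbon bound to an aromatic nitrogen now gives two further steps: a 1.5-fold higher number from compound 2 to compound 4 (0.17 log units; within the scatter) for 4-methylphenyl against 3-chlorophenyl, and a 4.0-fold lower number from compound 1 to compound 4 (0.61 log units; beyond the scatter) for 4-methylphenyl against 2,4-dichlorophenyl, leaving 2,4-dichlorophenyl as the only group here with steps beyond the scatter. No measurement available here bears on the reason for these steps.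

Open, going by these compounds, is how morpholine or piperazine, or a carboxylic acid, would read in place of these amines. Also open, on these data alone, is whether the amine exchange reads the same with 3-chlorophenyl or 2,4-dichlorophenyl in place of 4-methylphenyl.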